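This account rests on a few compounds, and the source may have more. Where it says the series, first, only, none or still open, it means among the compounds named here.

Compound 2 `COc1cc(C(F)(F)F)cc(C(F)(F)F)c1C(=O)NC1(c2ccccc2)CCCN(Cc2ccccc2)C1` has the shared core of this small set: an aromatic amide attached to a six-membered non-aromatic ring with one nitrogen, where that nitrogen carries a benzyl group. Among the measured compounds shown here, in an assay on cells for inhibition of sodium- and chloride-dependent glycine transporter 1 (Homo sapiens) (on this read-out lower numbers stand for an effect already at smaller amounts and higher numbers for an effect only at larger amounts of compound), compound 2 gives 6700 nM, the higher of the two numbers measured so far. Its nearest neighbour is compound 1 `COc1cc(C(F)(F)F)cc(C(F)(F)F)c1C(=O)NC1(c2ccccc2)CCCN(C2CCCC2)C1`, which carries a cyclopentyl group on the same nitrogen and in this assay gives 270 nM. The step of a 25-fold higher number from compound 1 to compound 2 (1.39 log units; beyond the scatter) is the only one measured, and it concerns the swap of cyclopentyl for benzyl.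

Compound 3 `COc1cc(C(F)(F)F)cc(C(F)(F)F)c1C(=O)NC1(c2ccccc2)CCCN(C(=O)c2ccccc2)C1` is not yet measured. It differs from compound 2 in that a benzoyl replaces the benzyl: benzoyl in place of benzyl on an amine nitrogen in a ring. The measured step does not bear directly on this change, since it alters a different part of the group on that nitrogen, so no step size can be read straight from the data. Still, the change turns the ring amine into an amide, and for compound 3 the expectation is a higher number than for compound 2, estimated as a 2.2-fold higher number from compound 2 to compound 3 (0.35 log units; beyond the scatter). The estimate for compound 3 is 15000 nM, with a range from 3000 nM to 60000 nM.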

Compound 3, half-maximal effective concentration: > 10000 nM
Compound 3: only a limit was reported (the forecaster's own chance of this, stated with the estimate: 40%); the middle value is on the limit's open side.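

The reading for compound 3 in this assay is a limit and not a number: the limit of > 10000 nM in this assay, at which 1 of the 3 values shown sits. Replacing benzyl with benzoyl on the ring nitrogen gives an at least 1.4-fold higher number from compound 2 to compound 3 (0.17 log units; that floor lies within the scatter), so this pair sets no order between the two groups, and adding a carbonyl to the benzyl group cannot be said to have moved the read-out in either direction. The comparison with the cyclopentyl group is clearer, with an at least 37-fold higher number from compound 1 to compound 3 (1.56 log units; beyond the scatter), so at this position both groups that carry a six-membered aromatic ring, in compound 2 and compound 3, give clearly higher numbers than the cyclopentyl group of compound 1.

Going by these compounds, how far compound 3 really lies beyond the limit remains unknown, and with it the true size of its steps from the other two compounds. Also open, on these data alone, is whether the carbonyl or the aromatic ring matters more on this nitrogen, a question that a cyclopentanecarbonyl group could address, while a small chain such as methyl or ethyl would show whether any ring is needed there at all.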